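This account rests on a few compounds, and the source may have more. Where it says the series, first, only, none or still open, it means among the compounds named here.

Series notes. Compound 1 `O=C(O)CCCn1nc(-c2cccnc2)c2ccccc2c1=O` and compound 2 `CCn1nc(-n2ccnc2)c2ccccc2c1=O` share a core and have both been measured in an assay on isolated protein (Oryctolagus cuniculus) with Thromboxane-A synthase (Homo sapiens) as the target, tested at 1 uM; on this read-out higher numbers stand for more inhibition at the one concentration tested (going by the name of the read-out) and lower numbers for less inhibition. Compound 1 gives 73% in this assay. Compound 2 gives 53%, the lower of the two numbers, and the gap to compound 1 lies beyond the scatter. The two compounds differ in more than one place, so the two values only show where each stands.

Compound 3 `CCn1nc(-c2cnccn2)c2ccccc2c1=O` has not been measured. It differs from compound 2 in one place: pyrazin-2-yl in place of 1H-imidazol-1-yl on an aromatic carbon. For the measured compounds named here, with no measured pair of that kind to lean on, the step from compound 2 is expected to be small, upward if anything, and possibly not beyond the scatter; the expected step is a number 5 percentage points higher from compound 2 to compound 3 (within the scatter). In this assay compound 3 is estimated at 58%, with a range from 32% to 82%.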

Compound 3, a percentage reported as inhibition, at one concentration (the size of the read-out at that concentration, not a potency): 37%
Compound 3: middle estimate off by 21 percentage points, on the high side; the range from low to high includes it.
By their numbers in this assay, from the lowest: compound 3; then compound 2; then compound 1.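

In this assay, for the compounds shown here, pyrazin-2-yl in place of 1H-imidazol-1-yl on this aromatic carbon gives a number 16 percentage points lower from compound 2 to compound 3 (beyond the scatter), the only comparison that differs in a single place. The value at this position therefore depends on which aromatic ring sits there, even though the two groups have the same counts of hydrogen-bond donors and acceptors and neither carries a net charge. No measurement shown here bears on what lies behind this step.

A single pair cannot separate the change from a five-membered to a six-membered ring from the different placement of the ring nitrogens. Going by these compounds, it also remains open how a phenyl ring or an amine on this aromatic carbon would compare, and whether a propyl chain in place of the ethyl group would alter the step.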